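Amide to urea in a pyrazole growth-inhibition series

The compounds below may be only part of what the source reports. "The series", "measured", "known", "first", "only" and "open" are said of these compounds alone.

Among the compounds with values here, compound 1 `COc1cc(-c2nn(-c3cccc(NC(=O)c4cccc(C(F)(F)F)c4)c3)cc2-c2ccncc2)ccc1Cl` is one of two compounds measured so far in a functional assay on NCI-H23 cells (Homo sapiens) for inhibition, read by sulforhodamine B assay, with a stated time of 48 h (a higher number here means a weaker inhibitor of growth, a lower number a stronger inhibitor of growth), where compound 1 gives 1560 nM. Compound 2 `O=C(Nc1cccc(-n2cc(-c3ccncc3)c(-c3ccc(Cl)c(O)c3)n2)c1)Nc1cc(C(F)(F)F)cc(C(F)(F)F)c1`, which carries a urea rather than an amide, gives 1020 nM in this assay, a value within the scatter of compound 1. Compound 3 `COc1cc(-c2nn(-c3cccc(NC(=O)Nc4ccc(Cl)c(C(F)(F)F)c4)c3)cc2-c2ccncc2)ccc1Cl` is not yet measured; it differs from compound 1 by (4-chloro-3-(trifluoromethyl)phenyl)amino in place of 3-(trifluoromethyl)phenyl on a carbonyl carbon. Given that compound 2 gives 1020 nM with a related urea, the step of a 2.2-fold lower number from compound 1 to compound 3 (0.35 log units; beyond the scatter) is expected to be small and towards a lower number, barely beyond the scatter. For compound 3 the estimate is 700 nM, within 250 nM to 2000 nM.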

Compound 3, concentration for 50% growth inhibition: 1310 nM
Compound 3: middle estimate off by 1.9-fold (0.27 log units), on the low side, and the stated range covers the measured number.
By their numbers in this assay, from the lowest: compounds 2, 3 and 1 (each within the scatter of the next).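

Replacing 3-(trifluoromethyl)phenyl on the carbonyl carbon with (4-chloro-3-(trifluoromethyl)phenyl)amino gives a 1.2-fold lower number from compound 1 to compound 3 (0.08 log units; within the scatter) in this assay. This position therefore takes the larger group, with its added hydrogen-bond donor, and growth inhibition stays within the scatter. No measurement here offers a reason for this result. The step joins two changes, the amino link and the chlorine, so their separate shares cannot be read. Going by these compounds, whether a methyl or a chain ending in a dimethylamine on this carbonyl carbon would hold this level remains open.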